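The source may report more compounds than this note shows. Statements on the series, on what has been measured and on what is new or still open speak of the compounds shown alone.

In a functional assay on EBC-1 cells (Homo sapiens) for antiproliferative activity, with a stated time of 72 h (on this read-out higher numbers stand for weaker inhibition and lower numbers for stronger inhibition), three compounds sharing one core have been measured. Compound 1 (`OCCn1cc(-c2cc(F)c3ncc(Cc4ccc5ncccc5c4)n3c2)cn1`), which carries a 1-(2-hydroxyethyl)-1H-pyrazol-4-yl group, gives 0.34 nM. Compound 2 (`COc1ccc(-c2cc(F)c3ncc(Cc4ccc5ncccc5c4)n3c2)cc1F`), with a 3-fluoro-4-methoxyphenyl group in that place, gives 407 nM, and compound 3 (`CNC(=O)c1cccc(-c2cc(F)c3ncc(Cc4ccc5ncccc5c4)n3c2)c1`), with a 3-(methylcarbamoyl)phenyl group, gives 400 nM. Compound 2 therefore sits at the high, weaker end of these numbers, level with compound 3 and far from compound 1.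

Compound 4 (`O=C(NCCCN1CCCC1)c1ccc(-c2cc(F)c3ncc(Cc4ccc5ncccc5c4)n3c2)cc1F`) keeps the rest of compound 2 but has (3-(pyrrolidin-1-yl)propyl)carbamoyl in place of methoxy, on an aromatic carbon ortho to a fluoro group: (3-(pyrrolidin-1-yl)propyl)carbamoyl in place of methoxy on an aromatic carbon. Among the measured compounds shown here, no measured step makes this exact change. The nearest guide is a 1.0-fold lower number from compound 2 to compound 3 (0.01 log units; within the scatter), a swap between two substituted phenyl groups, the second of which also carries a carbamoyl group, and it made no real difference. The steps of a 1200-fold higher number from compound 1 to compound 2 (3.08 log units; beyond the scatter) and a 1200-fold higher number from compound 1 to compound 3 (3.07 log units; beyond the scatter) show that changes at this part of the molecule can be very large, so the uncertainty is wide. With compound 2 at the top of the measured numbers, a moderate move towards stronger inhibition is expected, namely a 2.7-fold lower number from compound 2 to compound 4 (0.43 log units; beyond the scatter). For compound 4 the estimated value is 150 nM, with an expected range from 25 nM to 900 nM.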

Compound 4, half-maximal inhibitory concentration: 161 nM
Estimate against measurement, compound 4: 1.1-fold (0.03 log units) below, and the stated range covers the measured number.
By their numbers in this assay, from the lowest: compound 1; then compound 4; then compounds 3 and 2 (each within the scatter of the next).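

Replacing a small methoxy with the much larger (3-(pyrrolidin-1-yl)propyl)carbamoyl, on an aromatic carbon ortho to a fluoro group, gives a 2.5-fold lower number from compound 2 to compound 4 (0.40 log units; beyond the scatter). Among the compounds shown here, the earlier swap between two substituted phenyl groups had stayed within the scatter, so this is the first change among the phenyl compounds that moves the number beyond it, and it shows that this position accepts a group of this size with a modest gain rather than a loss in this assay, although compound 1 at 0.34 nM still holds the lowest number by far. The data offer no measurement that accounts for this shift.

For the compounds shown here, the single step changes several things at once, so it leaves open which part of the new group matters: the amide, the propyl chain or the pyrrolidine ring. A plain methylcarbamoyl at this same place, a shorter ethyl chain, or a piperidine or dimethylamino group in place of the pyrrolidine would separate these parts, and a carboxylic acid there would test whether the amide is needed at all.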